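The source may report more compounds than this note shows. Statements on the series, on what has been measured and on what is new or still open speak of the compounds shown alone.

Measured so far:
- compound 1 `CCCCc1ccc(CNC(C)=O)c(=O)n1Cc1ccc(-c2ccccc2-c2nn[nH]n2)cc1`: 3 nM
- compound 2 `CCCCc1ccc(CN(CC)S(C)(=O)=O)c(=O)n1Cc1ccc(-c2ccccc2-c2nn[nH]n2)cc1`: 2 nM

Both compounds share the same core and are measured in a functional assay (aorta) for antagonist activity, with Oryctolagus cuniculus as the target; on this read-out higher numbers stand for weaker inhibition and lower numbers for stronger inhibition. Among the compounds with values here, compound 1 gives 3 nM and compound 2 gives 2 nM; the only measured step, a 1.5-fold lower number from compound 1 to compound 2 (0.18 log units; within the scatter), puts the two within the scatter of each other, so neither can be set apart from the other on these numbers.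

Compound 3 `CCCCc1ccc(CN(C)S(C)(=O)=O)c(=O)n1Cc1ccc(-c2ccccc2-c2nn[nH]n2)cc1` is not yet measured. It differs from compound 2 by hydrogen in place of methyl on a saturated chain carbon bound to a sulfonamide nitrogen, that is, ethyl to methyl on the sulfonamide nitrogen of the (ethyl(methylsulfonyl)amino)methyl group. Within the data shown here, no measured step touches this position directly. Among the measured compounds shown here, the one step available, from acetamido to ethyl(methylsulfonyl)amino, was itself within the scatter, so the series gives no sign that changes at this substituent move this assay much. A shortening of the chain on the nitrogen by one carbon is expected to give a step of a 1.3-fold higher number from compound 2 to compound 3 (0.10 log units; within the scatter) that stays within the scatter. Compound 3 is therefore estimated at 2.5 nM, with a range of 1 nM to 6 nM.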

Compound 3, half-maximal inhibitory concentration: 0.2 nM
Compound 3: the middle estimate sits 13-fold (1.10 log units) above what was measured, and the stated range ends above it.
By their numbers in this assay, from the lowest: compound 3; then compounds 2 and 1 (each within the scatter of the next).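

In this assay, the substituent on the sulfonamide nitrogen turns out to be a sensitive point: ethyl to methyl, a loss of 1 carbon, gives a 10-fold lower number from compound 2 to compound 3 (1.00 log units; beyond the scatter), whereas the earlier acetamido to ethyl(methylsulfonyl)amino change stayed within the scatter and gave no sign of this. Set against the acetamido group, methyl(methylsulfonyl)amino gives a 15-fold lower number from compound 1 to compound 3 (1.18 log units; beyond the scatter), so among these compounds, replacing acetamido with a sulfonamide does not by itself separate the numbers, and the separation appears only with methyl on the sulfonamide nitrogen. Within the data shown here, nothing at hand bears on why removing this 1 carbon moves the number so far.

From the compounds shown here alone, it remains open whether the number follows the length of the chain on this nitrogen, which a propyl group or the bare sulfonamide hydrogen in place of methyl would test. Going by these compounds, it is equally open whether methyl brings a similar step on the amide side, as N-methylacetamido would show, or whether the gain depends on the methylsulfonyl group, which an ethylsulfonyl group would probe.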